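A few compounds are considered here, and "the series" means these few. Any claim that something is new, unique, unknown or untested is made for them only; others in the source may bear on it.

Measured in a functional assay on the whole organism (Hindlimb, strain albino) with Mus musculus as the target, in the maximal electroshock model, with a stated time of 0.5 h; on this read-out higher numbers stand for an effect only at larger amounts of compound and lower numbers for an effect already at smaller amounts:
- compound 1 `CC(=O)N1N=C(Nc2nc3ccc(Cl)cc3s2)CC1c1ccccc1` gives 161 umol/kg
- compound 2 `O=C(/C=C/c1ccccc1)Nc1nc2ccc(Cl)cc2s1` gives 425 umol/kg
- compound 3 `CC(=O)N1N=C(Nc2nc3ccc([N+](=O)[O-])cc3s2)CC1c1ccccc1` gives 216 umol/kg

Compound 1 carries the lowest of these three numbers, although its gap to compound 3 does not exceed the scatter. Compound 2 shows a clearly larger number than compound 1. The next compound to be tested is compound 4 `CC(=O)N1N=C(Nc2nc3ccc(Cl)cc3s2)CC1c1ccc(Cl)cc1`, which departs from compound 1 by one change: chloro in place of hydrogen on an aromatic carbon. In words, chloro takes the place of hydrogen on an aromatic carbon, turning phenyl into 4-chlorophenyl.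

Going by the values given here, only one measured step compares two compounds that differ in a single place: a 1.3-fold higher number from compound 1 to compound 3 (0.13 log units; within the scatter). That step swaps chloro for nitro and leaves the phenyl untouched, so it bears on the new change only loosely. It does show that one substitution on an aromatic carbon of compound 1 moved the number by no more than the scatter. Among the compounds with values here, no measured compound carries a substituent on the phenyl, so the direction of any shift remains open, and no step beyond the scatter is expected. The expected step is a 1.2-fold lower number from compound 1 to compound 4 (0.06 log units; within the scatter), and it would stay within the scatter. For compound 4 the estimated value is 140 umol/kg, with an expected range from 60 umol/kg to 330 umol/kg.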

Compound 4, dose for half-maximal effect: 79.5 umol/kg
The estimate for compound 4 lay 1.8-fold (0.25 log units) above the measured number, within the range that was stated.
By their numbers in this assay, from the lowest: compound 4; then compounds 1, 3 and 2 (each within the scatter of the next, the first and the last beyond it).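

In this assay, the phenyl of compound 1 proves to be a place where one added atom can shift the number beyond the scatter: turning phenyl into 4-chlorophenyl gives a 2.0-fold lower number from compound 1 to compound 4 (0.31 log units; beyond the scatter), a modest step that rests on this single pair. Going by these compounds alone, the only earlier step, a 1.3-fold higher number from compound 1 to compound 3 (0.13 log units; within the scatter), changed a different aromatic substituent and left the phenyl untouched, so it stayed within the scatter and said nothing about this position, whereas the new step shows that a substituent on the phenyl is tolerated in this assay and goes with an effect at a smaller amount of compound. Nothing in the available data accounts for this shift.

From the compounds shown here alone, whether the lower number belongs to chloro itself or would also come with other groups at this position, such as methoxy, an amine or a carboxylic acid, remains open, as does the outcome of placing chloro on another carbon of the phenyl. Going by these compounds, it is equally open whether the same change would give a step of similar size on compound 3, which carries nitro instead of chloro on the core.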